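From compound 3 to compound 4: a rearranged side chain

The compounds below may be only part of what the source reports. "The series", "measured", "known", "first", "only" and "open" are said of these compounds alone.

The compounds share one core and differ in the side chain. In an ADME assay on microsomes from liver (Mus musculus) for metabolic stability, read by mass spectrometry, with a stated time of 40 min, tested at 1 uM (on this read-out higher numbers stand for a more stable compound and lower numbers for a less stable compound), compound 1 (`COc1cc(N2CCN(C(=O)N3CCN(C)CC3)CC2)ccc1Nc1nc(NC2CCCCC2)c2nc[nH]c2n1`) gives 46% as its reading, and compound 2 (`COc1cc(N2CCN(C(=O)N3CCC(O)C3)CC2)ccc1Nc1nc(NC2CCCCC2)c2nc[nH]c2n1`) gives 47% as its reading. Compound 3 (`COc1cc(N2CCC(C(=O)N3CCC(N(C)C)C3)CC2)ccc1Nc1nc(NC2CCCCC2)c2nc[nH]c2n1`) gives 60% as its reading, the highest of the three numbers and beyond the scatter from each of the other two.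

Compound 4 (`COc1cc(N2CCC(CC(=O)N3CCN(C)CC3)CC2)ccc1Nc1nc(NC2CCCCC2)c2nc[nH]c2n1`) has the same atoms as compound 3, joined differently. It carries ((4-methylpiperazin-1-yl)carbonyl)methyl in place of (3-(dimethylamino)pyrrolidin-1-yl)carbonyl on a saturated ring carbon.

Among the measured compounds shown here, the one measured step that bears on this is a number 1 percentage points higher from compound 1 to compound 2 (within the scatter) for 3-hydroxypyrrolidin-1-yl in place of 4-methylpiperazin-1-yl on a carbonyl carbon. For the measured compounds named here, that exchange showed no movement beyond the scatter, but it does not test the entering group itself, and no measured pair does. Going by the values given here, compound 1, the only measured compound with 4-methylpiperazin-1-yl, gives 46% as its reading, which pulls the expectation down from compound 3. A small downward move is therefore expected, with a number 8 percentage points lower from compound 3 to compound 4 (within the scatter) as the estimated step in this assay for now. For compound 4 the expected reading is 52% within an estimated range of 38% to 66% as the likely span.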

Compound 4, percent of the compound remaining: 43%
Estimate against measurement, compound 4: 9 percentage points above, and the stated range covers the measured number.
By their numbers in this assay, from the lowest: compounds 4, 1 and 2 (each within the scatter of the next); then compound 3.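

In this assay, the side chain on the saturated ring carbon gives a number 17 percentage points lower from compound 3 to compound 4 (beyond the scatter), although the group that leaves and the group that enters hold the same atoms, joined differently. Among the compounds shown here, the earlier measured step, a number 1 percentage points higher from compound 1 to compound 2 (within the scatter), was an exchange on a carbonyl carbon that stayed within the scatter, so this is the first step showing that the arrangement of the side chain at this position can move the reading beyond the scatter. No measurement shown here explains this step, and its origin remains unassigned.

The step replaces the five-membered ring with the six-membered ring and also adds the methyl link to the carbonyl, so the compounds shown cannot separate the two changes. Going by these compounds, how (4-methylpiperazin-1-yl)carbonyl or ((3-(dimethylamino)pyrrolidin-1-yl)carbonyl)methyl would read on the same saturated ring carbon remains open, and either group would put one of the two changes on its own.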